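The compounds below may be only part of what the source reports. "The series", "measured", "known", "first", "only" and "open" are said of these compounds alone.

In a functional assay on isolated protein for agonist activity at Glucose-dependent insulinotropic receptor (Homo sapiens), read by HTRF and cAMP accumulation (on this read-out higher numbers stand for larger maximal responses and lower numbers for smaller maximal responses), compound 1 `CC1(OC(=O)N2CCC(O[C@H]3CC[C@H](Oc4cnc(S(C)(=O)=O)cn4)CC3)CC2)CC1` gives 118%, compound 2 `C[C@@H](CF)OC(=O)N1CCC(O[C@H]2CC[C@H](Oc3cnc(S(C)(=O)=O)cn3)CC2)CC1` gives 105%, and compound 3 `CS(=O)(=O)c1cnc(O[C@H]2CC[C@H](OC3CCN(CC4(C(F)(F)F)CC4)CC3)CC2)cn1` gives 116%. Compound 3 thus stands second highest of the three maximal responses, within the scatter of compound 1 and beyond the scatter of compound 2. Compound 4 `CS(=O)(=O)c1cnc(O[C@H]2CC[C@H](OC3CCN(CC4(C(F)(F)F)CCCC4)CC3)CC2)cn1` has not yet been measured; it differs from compound 3 in one place: a group of 9 heavy atoms (6 carbon, 3 fluorine; one five-membered non-aromatic ring of carbon only) in place of a group of 7 heavy atoms (4 carbon, 3 fluorine; one three-membered non-aromatic ring of carbon only), on a saturated chain carbon bound to an amine nitrogen in a ring. Going by the values given here, none of the measured steps changes a ring size on this chain carbon, so the evidence is indirect. The closest steps exchange the whole group on the ring amine nitrogen, a number 2 percentage points lower from compound 1 to compound 3 (within the scatter) and a number 11 percentage points higher from compound 2 to compound 3 (beyond the scatter), while a number 13 percentage points lower from compound 1 to compound 2 (beyond the scatter) concerns the carbamate of compound 1. All three measured compounds sit in a narrow band of maximal response, so the step of a number 2 percentage points lower from compound 3 to compound 4 (within the scatter) is expected to stay within the scatter. Compound 4 is therefore estimated to give 114% in this assay, with a range from 100% to 126%.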

Compound 4, largest response reached (Emax), in percent of the reference or control that the assay uses: 37%
Estimate against measurement, compound 4: 77 percentage points above, and the stated range ends above it.
By their numbers in this assay, from the lowest: compound 4; then compound 2; then compounds 3 and 1 (each within the scatter of the next).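

In this assay, going by these compounds alone, the ring on the saturated chain carbon bound to an amine nitrogen in a ring proves decisive: with the trifluoromethyl kept, a five-membered carbon ring in place of the three-membered one gives a number 79 percentage points lower from compound 3 to compound 4 (beyond the scatter) and takes the response out of the narrow band the earlier compounds shared. The two carbamates stand far from it as well, with a number 81 percentage points lower from compound 1 to compound 4 (beyond the scatter) and a number 68 percentage points lower from compound 2 to compound 4 (beyond the scatter) on exchange of the whole group on the ring amine nitrogen, so exchanges there, within the scatter or modest before, can also be large. Nothing measured here accounts for this loss.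

On these data alone, how a cyclobutane or cyclohexane ring on this carbon would respond remains open, so whether the response falls gradually or abruptly with ring size cannot be said. Equally open, as far as these compounds go, is whether a methyl in place of the trifluoromethyl on the five-membered ring would give the same low response.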